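Piperazinyl in place of aminophenylamino on the shared core

The source may hold more compounds than are shown below. What is called first, only, known or untested is meant among the compounds shown, and "the series" means these compounds.

Of the compounds shown here, two of one series have been tested in a functional assay on MCF7 cells (Homo sapiens) for cytotoxicity, read by MTT assay, with a stated time of 72 h; a higher number here means a weaker inhibitor, a lower number a stronger inhibitor. Compound 1, `Nc1ccc(Nc2c(C(=O)NCc3ccc(F)cc3)nc(Br)c3cccnc23)cc1`, gives 4000 nM in this assay, the lower of the two numbers. Compound 2, `CN(C)c1ccc(CNC(=O)c2nc(Br)c3cccnc3c2N[C@H]2CC[C@H](N)CC2)cc1`, gives 5000 nM in this assay, a result that sits within the scatter of compound 1, so the two cannot be placed in order of potency on this evidence.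

The third member, compound 3, `O=C(NCc1ccc(F)cc1)c1nc(Br)c2cccnc2c1N1CCNCC1`, has not yet been measured. Relative to compound 1 it differs at a single position: piperazin-1-yl in place of (4-aminophenyl)amino on an aromatic carbon. Among the measured compounds shown here, no measured pair in the set shows what such a swap does here, so the direction and size of the step rest on judgment alone. The change removes one hydrogen-bond donor and the aromatic ring of the leaving group, while keeping two acceptors in the entering group.

For compound 3 the step of a 1.5-fold higher number from compound 1 to compound 3 (0.18 log units; within the scatter) is expected to be small, at most slightly toward a weaker inhibitor. Compound 3 is therefore estimated at 6000 nM in this assay, with a likely range from 2000 nM to 20000 nM.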

Compound 3, half-maximal inhibitory concentration: 7000 nM
The estimate for compound 3 lay 1.2-fold (0.07 log units) below the measured number; the measured number falls inside the stated range.
By their numbers in this assay, from the lowest: compounds 1, 2 and 3 (each within the scatter of the next).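

Among the compounds shown here, the one pair that differs in a single place shows a 1.8-fold higher number from compound 1 to compound 3 (0.24 log units; within the scatter) in this assay, so this swap has a measured size for the first time. On this aromatic carbon, para to a bromo group, piperazin-1-yl can stand in for (4-aminophenyl)amino with no difference that this assay can separate from repeat scatter, even though a six-membered aromatic ring of carbon only gives way to a non-aromatic ring with 2 hetero atoms and one hydrogen-bond donor is lost. For compound 1 and compound 3, then, an aromatic ring in this substituent is not needed to keep the reading at this level, although no information is available on what lies behind this result.

The compounds shown leave open whether any group on this carbon can move the number beyond the scatter, since this single step cannot settle that for the position as a whole. A morpholin-4-yl or 4-methylpiperazin-1-yl group, or an open-chain amine such as 2-aminoethylamino, would test whether the free ring nitrogen of piperazin-1-yl or the ring itself matters here.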